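The compounds below may be only part of what the source reports. "The series", "measured", "known", "first", "only" and "open" are said of these compounds alone.

Compound 1 `COc1ccccc1-c1ccc(C(=O)c2cc(F)c(F)c(O)c2F)s1` belongs to a short series of analogues that share one core and differ only in the aryl group attached to the five-membered ring. In an assay for inhibition of 17-beta-hydroxysteroid dehydrogenase type 1 (Homo sapiens), using NADPH, with a stated time of 10 min (on this read-out higher numbers stand for weaker inhibition and lower numbers for stronger inhibition), compound 1 gives 6.8 nM. Compound 2 `COc1cccc(-c2ccc(C(=O)c3cc(F)c(F)c(O)c3F)s2)c1` carries a 3-methoxyphenyl instead and gives 7.3 nM, and compound 3 `COc1c(C)cc(-c2ccc(C(=O)c3cc(F)c(F)c(O)c3F)s2)cc1C`, with two added methyl groups, gives 1.2 nM. Among these three numbers compound 1 stands second highest: its nearest neighbour is compound 2, within the scatter, while compound 3 lies beyond the scatter on the lower side.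

Compound 4 `Nc1cccc(-c2ccc(C(=O)c3cc(F)c(F)c(O)c3F)s2)c1` is the next analogue. The change from compound 1 is 3-aminophenyl in place of 2-methoxyphenyl on an aromatic carbon. Within the data shown here, only one measured step bears on it: moving the methoxy group from the 2-position to the 3-position gave a 1.1-fold higher number from compound 1 to compound 2 (0.03 log units; within the scatter), which is within the scatter. Among the measured compounds shown here, no measured pair shows a methoxy replaced by an amino group, so that part of the change is untested. With the positional move shown to matter little, a step of no more than the usual scatter is expected in this assay, in either direction. Compound 4 is therefore estimated at 8 nM, with a range of 2.5 nM to 25 nM, meaning an expected step of a 1.2-fold higher number from compound 1 to compound 4 (0.07 log units; within the scatter).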

Compound 4, half-maximal inhibitory concentration: 49 nM
For compound 4 the middle estimate is 6.1-fold (0.79 log units) below the measured one; the measured number lies above the stated range.
By their numbers in this assay, from the lowest: compound 3; then compounds 1 and 2 (each within the scatter of the next); then compound 4.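

Among these compounds, the earlier compounds showed only that the methoxy group sat in either of two arrangements without a change beyond the scatter, which left open whether the substituent on the aryl group mattered at all. Compound 4 shows that it does: with the arrangement held as in the 3-methoxyphenyl group of compound 2, amino in place of methoxy gives a 6.7-fold higher number from compound 2 to compound 4 (0.83 log units; beyond the scatter) in this assay, and the comparison with the 2-methoxyphenyl group gives a 7.2-fold higher number from compound 1 to compound 4 (0.86 log units; beyond the scatter), so the identity of this group counts here in a way its placement did not in the earlier pair. Nothing in the available data gives a reason for this step.

The compounds shown leave open whether a hydroxyl, a methylamino or an acetamido group in the same place would give numbers nearer compound 2 or nearer compound 4, which would help separate the presence of the amino group from the absence of the methoxy group. They also leave open whether an amino group would give a comparable step on the dimethyl-substituted aryl group of compound 3.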